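Aryl swap on the shared core: compound 3 outlook

The compounds below may be only part of what the source reports. "The series", "measured", "known", "first", "only" and "open" are said of these compounds alone.

Measured so far:
- compound 1, `CC1=NC(C)=C(C(=O)O)C(c2cccc(C)c2)/C1=C(\O)OC/C=C/c1ccccc1`: 1800 nM
- compound 2, `CC1=NC(C)=C(C(=O)O)C(c2cccc(F)c2)/C1=C(\O)OC/C=C/c1ccccc1`: 1300 nM

In a functional assay on IMR-32 cells for inhibition of Voltage-dependent N-type calcium channel subunit alpha-1B (Homo sapiens), read by calcium flux (a lower number here means a stronger inhibitor, a higher number a weaker inhibitor), compound 1 gives 1800 nM, the highest of the two numbers; the nearest is compound 2 at 1300 nM, and the step of a 1.4-fold lower number from compound 1 to compound 2 (0.14 log units; within the scatter) stays inside the scatter. Compound 3, `CC1=NC(C)=C(C(=O)O)C(c2ccsc2)/C1=C(\O)OC/C=C/c1ccccc1`, is not yet measured. It differs from compound 1 by thiophen-3-yl in place of 3-methylphenyl on a saturated ring carbon. Among the measured compounds shown here, the only step in hand that bears on this position is the one from compound 1 to compound 2, a fluoro in place of methyl on the same aromatic ring, and it was a 1.4-fold lower number from compound 1 to compound 2 (0.14 log units; within the scatter). That step replaces one group on the ring; compound 3 replaces the ring itself, so the precedent is weak. With no step beyond the scatter at this position, compound 3 is expected to land near compound 1, as a 1.2-fold lower number from compound 1 to compound 3 (0.08 log units; within the scatter). The estimate for compound 3 in this assay is 1500 nM, with a range of 600 nM to 4000 nM.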

Compound 3, half-maximal inhibitory concentration: 2900 nM
Estimate against measurement, compound 3: 1.9-fold (0.29 log units) below; the range from low to high includes it.
By their numbers in this assay, from the lowest: compounds 2, 1 and 3 (each within the scatter of the next, the first and the last beyond it).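

In this assay, the aromatic ring itself, and not only a group on it, has now been exchanged on the saturated ring carbon: thiophen-3-yl in place of 3-methylphenyl gives a 1.6-fold higher number from compound 1 to compound 3 (0.21 log units; within the scatter), so this five-membered ring with a sulfur is not told apart from 3-methylphenyl here. Against 3-fluorophenyl, the same exchange gives a 2.2-fold higher number from compound 2 to compound 3 (0.35 log units; beyond the scatter), the only step among these compounds beyond the scatter, and it is modest. No measurement in hand accounts for this step.

Still open, from the compounds shown here alone, is how an aromatic ring bearing an amine or a carboxylic acid, or a saturated ring such as cyclohexyl, would read at this carbon. Also open, going by these compounds, is whether the thiophen-3-yl steps hold when another part of the shared core is changed.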